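Swapping the 4-nitrobenzyl Group for Butyl

This account rests on a few compounds, and the source may have more. Where it says the series, first, only, none or still open, it means among the compounds named here.

Measured compounds:
Compound 1, `C=CCn1c(=O)n(C2OC(CO[Si](C)(C)C(C)(C)C)[C@@H](O)[C@H]2O)c2nc(N)nc(O)c21`: 1 uM
Compound 2, `Nc1nc(O)c2c(n1)n(C1OC(CO)[C@@H](O)[C@H]1O)c(=O)n2Cc1ccc([N+](=O)[O-])cc1`: 40 uM

Both compounds share one core and differ in the group on the ring nitrogen and in the protection of the sugar. In a functional assay (B cells) with Mus musculus as the target (on this read-out higher numbers stand for an effect only at larger amounts of compound and lower numbers for an effect already at smaller amounts), compound 1 gives 1 uM. In this assay compound 2 gives 40 uM, the higher of the two numbers, and the gap between compound 1 and compound 2 is beyond the scatter of this assay.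

Compound 3, `CCCCn1c(=O)n(C2OC(CO)[C@@H](O)[C@H]2O)c2nc(N)nc(O)c21`, has not been measured. It differs from compound 2 as follows:
propyl in place of 4-nitrophenyl on a saturated chain carbon bound to an aromatic nitrogen

Going by the values given here, no pair of measured compounds differs in this one place, so the size of the step cannot be read from the data. Compound 1, which carries a short chain on that nitrogen rather than an aromatic group, gives 1 uM, and from this a lower number for compound 3 is expected. The step from compound 2 to compound 3 is estimated as a 6.7-fold lower number from compound 2 to compound 3 (0.82 log units; beyond the scatter). For compound 3 a value of about 6 uM is expected, within 1.5 uM to 25 uM.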

Compound 3, concentration for half-maximal effect: 11 uM
Compound 3: the middle estimate sits 1.8-fold (0.26 log units) below what was measured; low and high end bracket the measured number.
By their numbers in this assay, from the lowest: compound 1; then compound 3; then compound 2.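

In this assay, the exchange of 4-nitrobenzyl for butyl gives a 3.6-fold lower number from compound 2 to compound 3 (0.56 log units; beyond the scatter). Compound 1 and compound 2 differ at the sugar as well as on the ring nitrogen, so their gap could not be tied to either place, whereas compound 2 and compound 3 share the same free sugar and differ only on this nitrogen. The group at this position therefore moves the number by itself, and a plain chain with no ring retains an effect in this read-out, although no measurement shown here gives a reason for the shift.

As far as these compounds go, this single step removes the aromatic ring and the nitro group together, so it remains open whether a plain benzyl group would sit nearer compound 2 or compound 3, and whether a longer chain such as hexyl would lower the number further. Compound 3 also differs from compound 1 in both the chain on this nitrogen and the protection of the sugar, so how much each of these contributes to the value of compound 1, 1 uM, cannot be read.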